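The source may report more compounds than this note shows. Statements on the series, on what has been measured and on what is new or still open speak of the compounds shown alone.

Working notes on the series, read in an ADME assay on Caco-2 cells (Homo sapiens) for permeability; on this read-out lower numbers stand for lower permeability and higher numbers for higher permeability. Compound 1 (`COc1ccc(/C=C/C(=O)N[C@@H]2O[C@H](CO)[C@@H](O)[C@H](O)[C@H]2O)c(O)c1`) gives 38.9 nm/s, compound 2 (`CC(C)(C)c1ccc(/C=C/C(=O)N[C@@H]2O[C@H](CO)[C@@H](O)[C@H](O)[C@H]2O)cc1`) gives 87.7 nm/s and compound 3 (`C[C@@H](Cc1ccc(C(C)(C)C)cc1)C(=O)N[C@@H]1O[C@H](CO)[C@@H](O)[C@H](O)[C@H]1O`) gives 100 nm/s. Compound 2 stands level with compound 3 within the scatter, while compound 1 lies lower, beyond the scatter.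

Compound 4 (`CCc1ccc(/C=C/C(=O)N[C@@H]2O[C@H](CO)[C@@H](O)[C@H](O)[C@H]2O)cc1`) is still unmeasured. It keeps the core of compound 2 and differs in one place: ethyl in place of tert-butyl on an aromatic carbon, with ethyl in place of tert-butyl on an aromatic carbon, para to a large group.

For the measured compounds named here, no measured pair isolates this change, so its size cannot be read directly. Going by the values given here, the only guide is the narrow spread of the measured values, from compound 1 at 38.9 nm/s to compound 3 at 100 nm/s. The expected step, a 1.3-fold lower number from compound 2 to compound 4 (0.13 log units; within the scatter), is a small one downward, within the scatter. Compound 4 is estimated at 65 nm/s, with an expected range of 35 nm/s to 115 nm/s.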

Compound 4, apparent permeability: 94.7 nm/s
Estimate against measurement, compound 4: 1.5-fold (0.16 log units) below; the range from low to high includes it.
By their numbers in this assay, from the lowest: compound 1; then compounds 2, 4 and 3 (each within the scatter of the next).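

Ethyl in place of tert-butyl on an aromatic carbon, para to a large group, is the first change in this series that can be read directly: in this assay it gives a 1.1-fold higher number from compound 2 to compound 4 (0.03 log units; within the scatter). Between these two compounds, the exchange of alkyl groups at this position leaves the read-out level within the scatter, which the earlier compounds, differing in more than one place, could not show. No measurement available here bears on the reason for this result.

The compounds shown leave open whether ethyl in place of tert-butyl reads the same on the core of compound 3. They also leave open how a group of a different kind, such as an amine or a carboxylic acid, would read at this position.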